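The source may hold more compounds than are shown below. What is called first, only, known or untested is meant among the compounds shown, and "the series" means these compounds.

Measured compounds in a functional assay on DU-145 cells (Homo sapiens) for inhibition, read by trypan blue exclusion, with a stated time of 96 h; on this read-out lower numbers stand for stronger inhibition of growth and higher numbers for weaker inhibition of growth:

compound 1, `O=C(/C(=C\c1ccc(OC(F)(F)F)cc1)S(=O)(=O)c1ccc(Br)cc1)c1ccc(Br)cc1`, giving 25000 nM
compound 2, `O=C(/C(=C\c1ccc(I)cc1)S(=O)(=O)c1ccc(Br)cc1)c1ccc(Br)cc1`, giving 1000 nM
compound 3, `O=C(/C(=C\c1ccc(I)cc1)Sc1ccc(Br)cc1)c1ccc(Br)cc1`, giving 1000 nM

Compound 2 and compound 3 carry the same iodo group and give the same number at the digits printed; the difference between the two cores is not broken down here. Compound 1 is set apart from both by the change (trifluoromethoxy in place of iodo on an aromatic carbon), and the step of a 25-fold higher number from compound 2 to compound 1 (1.40 log units; beyond the scatter) marks how far compound 1 stands from compound 2 in this assay. The number of compound 3 is lower than that of compound 1 in the same measure.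

Compound 4, `O=C(/C(=C\c1ccc(OC(F)(F)F)cc1)Sc1ccc(Br)cc1)c1ccc(Br)cc1`, has not yet been measured. It differs from compound 3 by trifluoromethoxy in place of iodo on an aromatic carbon, which is the same change that separates compound 1 from compound 2, at the same kind of place. Among the compounds with values here, for compound 4 the step of a 25-fold higher number from compound 3 to compound 4 (1.40 log units; beyond the scatter) is expected, a step of about the same size as the one already seen, because a 25-fold higher number from compound 2 to compound 1 (1.40 log units; beyond the scatter) shows what this change did once; with only one earlier example the width of the expectation is kept broad. Compound 4 is therefore estimated at 25000 nM, most likely between 8000 nM and 70000 nM.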

Compound 4, concentration for 50% growth inhibition: 10000 nM
The estimate for compound 4 lay 2.5-fold (0.40 log units) above the measured number; the range from low to high includes it.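

In this assay the change of iodo to trifluoromethoxy on the aromatic carbon again moved the number upward, now on the core of compound 3, giving a 10-fold higher number from compound 3 to compound 4 (1.00 log units; beyond the scatter), and the two steps compare as follows: the same change on two cores in this assay, a 25-fold higher number (1.40 log units; beyond the scatter) from compound 2 to compound 1 and a 10-fold higher number (1.00 log units; beyond the scatter) from compound 3 to compound 4, 2.5-fold (0.40 log units) apart, within the scatter of two such steps

Within the data shown here, the change therefore carried over from the core of compound 2 to the core of compound 3 in direction and, within the scatter, in size, but this rests on only two pairs and shows neither why the change acts as it does nor that it would hold on any further core. At the other place, (4-bromophenyl)sulfanyl in place of (4-bromophenyl)sulfonyl gave a 2.5-fold lower number from compound 1 to compound 4 (0.40 log units; beyond the scatter), whereas compound 2 and compound 3, which carry iodo, stand level at the digits printed, so this swap of the linking group shows up only in the trifluoromethoxy pair.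

The compounds shown hold only iodo and trifluoromethoxy at this place on the ring, which leaves open how a chloro group, a methoxy group or an amine there would fare on either core. As far as these compounds go, all of them also keep both bromo groups, so it remains open whether the step would persist with a carboxylic acid or an amine in place of either bromo group.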